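Phenyl for Methoxy: Expecting the Number for Compound 3

This account rests on a few compounds, and the source may have more. Where it says the series, first, only, none or still open, it means among the compounds named here.

In an assay on isolated protein for inhibition of Aromatase (Homo sapiens), read by fluorescence and colorimetric assay, with a stated time of 30 min (a higher number here means a weaker inhibitor, a lower number a stronger inhibitor), compound 1 `N#Cc1ccc(OCc2cn(C(c3ccc(C#N)cc3)c3ccc(C#N)cc3)nn2)cc1` gives 4640 nM, and compound 2 `COc1ccc(OCc2cn(C(c3ccc(C#N)cc3)c3ccc(C#N)cc3)nn2)cc1` gives 12200 nM, the higher of the two numbers. For the measured compounds named here, the single measured step, a 2.6-fold higher number from compound 1 to compound 2 (0.42 log units; beyond the scatter), puts methoxy in place of cyano on an aromatic carbon. Going by the values given here, compound 3 `N#Cc1ccc(C(c2ccc(C#N)cc2)n2cc(COc3ccc(-c4ccccc4)cc3)nn2)cc1` differs from compound 2 by phenyl in place of methoxy on an aromatic carbon, a change with no measured counterpart, so the methoxy step is only a loose guide. Compound 3 is therefore expected to give 8000 nM, within 2500 nM to 25000 nM. The estimated step, a 1.5-fold lower number from compound 2 to compound 3 (0.18 log units; within the scatter), is expected to stay modest.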

Compound 3, half-maximal inhibitory concentration: 13400 nM
Beside the measured number, compound 3's estimate is 1.7-fold (0.22 log units) below it; measured number inside the range.
By their numbers in this assay, from the lowest: compound 1; then compounds 2 and 3 (each within the scatter of the next).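

At this aromatic carbon, para to a large group, phenyl in place of methoxy gives a 1.1-fold higher number from compound 2 to compound 3 (0.04 log units; within the scatter) in this assay and so adds a six-membered aromatic ring without moving the number beyond the scatter. Phenyl in place of cyano gives a 2.9-fold higher number from compound 1 to compound 3 (0.46 log units; beyond the scatter) and thus leaves only compound 1 apart among these three compounds, with methoxy and phenyl together at the higher numbers. Nothing available explains this result.

The compounds shown leave open whether an amine or a carboxylic acid at this carbon would stand with the cyano group or with methoxy and phenyl.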